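Capped pyrazole in place of free pyrazole on amide aryl

A few compounds are considered here, and "the series" means these few. Any claim that something is new, unique, unknown or untested is made for them only; others in the source may bear on it.

Compound 1, `CNC(=O)N1CCCc2ccc(NC(=O)c3cccc(-c4cn[nH]c4)c3)cc21`: 77.7% in a functional assay on MV4-11 cells (Homo sapiens) for antiproliferative activity, with a stated time of 6 days, tested at 6.25 uM; a lower number here means a weaker effect, a higher number a stronger effect of the compound at the concentration tested
Compound 2, `CNC(=O)N1CCCc2ccc(NC(=O)c3ccc(-c4ccn(S(C)(=O)=O)n4)cc3)cc21`: 57.2%

Compound 1 holds the highest of the two numbers, with compound 2 a step below it that lies beyond the scatter. Compound 3, `CNC(=O)N1CCCc2ccc(NC(=O)c3cccc(-c4ccn(C(C)=O)n4)c3)cc21`, awaits measurement. Its difference from compound 1 is 1-acetyl-1H-pyrazol-3-yl in place of 1H-pyrazol-4-yl on an aromatic carbon. Among the measured compounds shown here, no measured pair isolates this change; compound 2, which also carries a pyrazole capped at its ring nitrogen, gives the lower of the two values, so the step of a number 12.7 percentage points lower from compound 1 to compound 3 (beyond the scatter) is expected to run downward, of modest size, near the edge of the scatter. Compound 3 is estimated at 65%, within 42% to 84%.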

Compound 3, a percentage reported as inhibition, at one concentration (the size of the read-out at that concentration, not a potency): 87.6%
Beside the measured number, compound 3's estimate is 22.6 percentage points below it; measured number outside the range, above it.
By their numbers in this assay, from the lowest: compound 2; then compounds 1 and 3 (each within the scatter of the next).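

In this assay, 1-acetyl-1H-pyrazol-3-yl in place of 1H-pyrazol-4-yl on an aromatic carbon, meta to a large group, gives a number 9.9 percentage points higher from compound 1 to compound 3 (within the scatter). This position therefore tolerates an acetyl-capped pyrazole, and a hydrogen-bond donor on the pyrazole is not needed to keep the read-out at the concentration tested. Nothing at hand explains the result.

The step joins the acetyl cap to a change of attachment point on the pyrazole, so neither can be read alone. A 1-acetyl-1H-pyrazol-4-yl or 1-methyl-1H-pyrazol-3-yl group would separate the two.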